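Replacing an aryl ether with a fused aromatic ring

The source may hold more compounds than are shown below. What is called first, only, known or untested is meant among the compounds shown, and "the series" means these compounds.

The measured compounds:
- compound 1 `COc1cccc(Oc2ccc3c(NCCCNCc4cc(F)ccc4OC)ccnc3c2)c1`: 7100 nM
- compound 2 `COc1cccc(Oc2ccc3c(NCCCNCc4cccc(OC)c4O)ccnc3c2)c1`: 5300 nM
- compound 3 `FC(F)(F)c1ccc(-c2ccc3c(NCCCNCc4ccco4)ccnc3c2)cc1`: 3470 nM

Compound 2 stands second highest of the three numbers in an ADME assay on HepG2 cells (Homo sapiens) for cytotoxicity, read by luminescence, CellTiter-Glo and ATP content, with a stated time of 72 h; on this read-out higher numbers stand for an effect only at larger amounts of compound and lower numbers for an effect already at smaller amounts; its nearest neighbour is compound 1, and compound 3 lies furthest from it, yet both gaps are within the scatter. For the measured compounds named here, the only step between compounds differing in one place is a 1.3-fold lower number from compound 1 to compound 2 (0.13 log units; within the scatter), and it concerns the group on the saturated chain carbon bound to an amine nitrogen, not the site changed here.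

Compound 4 `COc1cccc(CNCCCNc2ccnc3cc(-c4cccc5ccccc45)ccc23)c1O` has not yet been measured in this assay. It differs from compound 2 by naphthalen-1-yl in place of 3-methoxyphenoxy on an aromatic carbon. Going by the values given here, no measured step bears directly on this position. Compound 3, whose shared core carries an aryl group at an aromatic carbon without an intervening oxygen, gives 3470 nM, which sits within the scatter of compound 2. The three measured values all fall within a narrow band, so no step beyond the scatter is expected for compound 4. The expected step is a 1.2-fold lower number from compound 2 to compound 4 (0.07 log units; within the scatter), which amounts to no change beyond the scatter. Compound 4 is therefore estimated at 4500 nM, with a range from 1800 nM to 11000 nM.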

Compound 4, half-maximal effective concentration: 2520 nM
For compound 4 the middle estimate is 1.8-fold (0.25 log units) above the measured one, and the stated range covers the measured number.
By their numbers in this assay, from the lowest: compounds 4, 3, 2 and 1 (each within the scatter of the next, the first and the last beyond it).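

In this assay, the change at this aromatic carbon gives a 2.1-fold lower number from compound 2 to compound 4 (0.32 log units; beyond the scatter), a modest step but the first among the compounds shown to lie beyond the scatter. For the compounds shown here, the earlier compounds offered no step at this position, so this is the first sign that the number responds to the group here while the rest of compound 2 stays the same: 3-methoxyphenoxy, with its two hydrogen-bond acceptors, leaves, and naphthalen-1-yl, with two six-membered aromatic rings of carbon only and no hydrogen-bond acceptors, enters. Nothing among the data shown explains why the number moves at this position.

The single change removes the ether oxygen and brings in a second fused ring at once, so the compounds shown cannot separate the two, and a plain phenyl, a naphthalen-2-yl or a benzyloxy group on the same carbon would be needed to tell them apart. From the compounds shown here alone, it also remains open whether the same step would appear with the 5-fluoro-2-methoxyphenyl group of compound 1 on the chain, or with an amide in place of the chain's secondary amine.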